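The source may report more compounds than this note shows. Statements on the series, on what has been measured and on what is new or still open speak of the compounds shown alone.

Three compounds of this series have numbers in a functional assay on A549 cells (Homo sapiens) for cytotoxicity, read by MTT assay, with a stated time of 72 h (a lower number here means a stronger inhibitor, a higher number a weaker inhibitor), so far. Compound 1 `O=C1c2c[n+]([O-])c3ccccc3c2C(=O)c2c1c1ccccc1n2CCCCN1CCCCC1` gives 150 nM and stands lowest of the three. Compound 2 `CC1(C)OC[C@@H](Cn2cc(Cn3c4c(c5ccccc53)C(=O)c3c[n+]([O-])c5ccccc5c3C4=O)nn2)O1` gives 4700 nM, and compound 3 `CC1(C)OC[C@H](Cn2cc(Cn3c4c(c5ccccc53)C(=O)c3c[n+]([O-])c5ccccc5c3C4=O)nn2)O1` gives 340 nM. Among the compounds with values here, the one step between compounds that differ in a single place is a 14-fold lower number from compound 2 to compound 3 (1.14 log units; beyond the scatter), which rests on the fact that compounds 2 and 3 differ only in the configuration as drawn and nothing else; it concerns the acetonide side chain and not the chain that carries the basic amine.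

Compound 4 `CCCN1CCN(CCCCn2c3c(c4ccccc42)C(=O)c2c[n+]([O-])c4ccccc4c2C3=O)CC1` has not been measured. It differs from compound 1 by 4-propylpiperazin-1-yl in place of piperidin-1-yl on a saturated chain carbon, four bonds along the chain from an aromatic nitrogen. Within the data shown here, no measured pair touches this end of the chain, so the step from compound 2 to compound 3 does not bear on it, and the exchange of one saturated amine ring for another at the same chain position gives no ground to expect a shift beyond the scatter in either direction. The expected step is therefore a 1.3-fold higher number from compound 1 to compound 4 (0.12 log units; within the scatter), small and uncertain in sign. For compound 4 the estimate in this assay is 200 nM, with a range from 60 nM to 650 nM.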

Compound 4, half-maximal inhibitory concentration: 320 nM
For compound 4 the middle estimate is 1.6-fold (0.20 log units) below the measured one, within the range that was stated.
By their numbers in this assay, from the lowest: compound 1; then compounds 4 and 3 (each within the scatter of the next); then compound 2.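

Within the data shown here, replacing piperidin-1-yl with 4-propylpiperazin-1-yl on a saturated chain carbon, four bonds along the chain from an aromatic nitrogen, gives the first measured change at the amine end of the chain: in this assay there is a 2.1-fold higher number from compound 1 to compound 4 (0.33 log units; beyond the scatter), a modest step beyond the scatter. This position therefore accepts the larger ring group with only a limited rise in the number. Nothing on hand accounts for this step.

On these data alone, the pair does not separate the second ring nitrogen from the propyl group, so piperazin-1-yl and 4-methylpiperazin-1-yl at the same place remain open. Also open, as far as these compounds go, is how morpholin-4-yl, a dimethylamino group or a longer chain carrying piperidin-1-yl would read in this assay, and whether the order of the two configurations holds with other side chains.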